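Pyrazolyl enone series: methoxy pattern on the aryl ring

The source may hold more compounds than are shown below. What is called first, only, known or untested is meant among the compounds shown, and "the series" means these compounds.

Two members of this series have been run so far in a functional assay on MOLT-4 cells (Homo sapiens) for cytotoxicity, read by sulforhodamine B assay, with a stated time of 48 h, tested at 0.1 uM; on this read-out higher numbers stand for a weaker effect at the one concentration tested and lower numbers for a stronger effect. Compound 1 `COc1ccc(-c2cc(/C=C/C(=O)c3ccc(N)cc3)[nH]n2)cc1` gives 98%, and compound 2 `COc1cc(-c2cc(/C=C/C(=O)c3ccc(N)cc3)[nH]n2)cc(OC)c1OC` gives 102%. Compound 2 carries the top number of the pair, yet compound 1 sits within the usual scatter of it, so no order between the two can be read; both read-outs amount to an effect that is barely distinguishable from none at the concentration used.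

Compound 3 `COc1ccc(-c2cc(/C=C/C(=O)c3ccc(N)cc3)[nH]n2)cc1OC` has not yet been run in this assay. Relative to compound 2 it differs as follows: hydrogen in place of methoxy on an aromatic carbon.

Among the compounds with values here, no step between measured compounds is on hand to calibrate this change. Within the data shown here, since compound 1, with its single methoxy group, and compound 2, with three, return values that overlap, the expected step from compound 2 to compound 3 is none beyond the scatter, a number 3 percentage points lower from compound 2 to compound 3 (within the scatter). Compound 3 is accordingly estimated at 99% in this assay, with a range from 88% to 108%.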

Compound 3, a percentage reported as activity, at one concentration (the size of the read-out at that concentration, not a potency): 106%
Compound 3: the middle estimate sits 7 percentage points below what was measured; measured number inside the range.
By their numbers in this assay, from the lowest: compounds 1, 2 and 3 (each within the scatter of the next).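

In this assay, within the data shown here, hydrogen in place of methoxy on the aromatic carbon ortho to a methoxy group gives a number 4 percentage points higher from compound 2 to compound 3 (within the scatter) and supplies the first calibrated step for this change. On the same ring, methoxy in place of hydrogen gives a number 8 percentage points higher from compound 1 to compound 3 (within the scatter), so among these three compounds a single methoxy change, whether removal or addition, leaves the read-out unmoved beyond the scatter. Nothing on hand offers an explanation for this result.

From the compounds shown here alone, whether the methoxy pattern matters at all remains open, since a single concentration at which all three compounds show barely any effect cannot separate them. Also open, going by these compounds, is whether a hydroxyl group, a chlorine atom or an amine on this carbon would move the read-out beyond the scatter.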